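This account rests on a few compounds, and the source may have more. Where it says the series, first, only, none or still open, it means among the compounds named here.

Of the compounds shown here, three built on one shared core have been measured in an ADME assay on HepG2 cells (Homo sapiens) for cytotoxicity, read by luminescence, CellTiter-Glo and ATP content, with a stated time of 72 h; a lower number here means that less compound is needed, a higher number that more compound is needed for the effect. Compound 1 `COc1ccc(F)cc1CNCCCNc1ccnc2cc(CCc3ccccc3)ccc12` gives 4240 nM, compound 2 `COc1ccc(F)cc1CNCCCNc1ccnc2cc(Cc3ccc(F)cc3)ccc12` gives 3530 nM, and compound 3 `COc1ccc(F)cc1CNCCCNc1ccnc2cc(Cc3ccccc3)ccc12` gives 7990 nM. Compound 3 sits at the top of these three numbers: a 2.3-fold higher number from compound 2 to compound 3 (0.35 log units; beyond the scatter), whereas a 1.9-fold higher number from compound 1 to compound 3 (0.28 log units; within the scatter). Compound 4 `COc1ccc(F)cc1CNCCCNc1ccnc2cc(-c3cccc4ccccc34)ccc12` differs from compound 3 in one place: naphthalen-1-yl in place of benzyl on an aromatic carbon. Among the measured compounds shown here, no measured step places an aromatic ring directly on the core, so the guides are loose: the nearest, which also changed the group on the core, is a 1.9-fold higher number from compound 1 to compound 3 (0.28 log units; within the scatter), and on the other ring a 1.2-fold lower number from compound 1 to compound 2 (0.08 log units; within the scatter). A small step or none beyond the scatter is therefore expected in this assay, namely a 1.3-fold lower number from compound 3 to compound 4 (0.12 log units; within the scatter). For compound 4 the estimate is 6000 nM, within 2500 nM to 15000 nM.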

Compound 4, half-maximal effective concentration in the HepG2 assay: 16000 nM
Beside the measured number, compound 4's estimate is 2.7-fold (0.43 log units) below it; the whole stated range lies below it.
By their numbers in the HepG2 assay, from the lowest: compounds 2, 1, 3 and 4 (each within the scatter of the next, the first and the last beyond it).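

In the HepG2 assay, naphthalen-1-yl on this aromatic carbon gives a 2.0-fold higher number from compound 3 to compound 4 (0.30 log units; within the scatter), no clear change from benzyl, while the gaps to the other two groups are clear: a 4.5-fold higher number from compound 2 to compound 4 (0.66 log units; beyond the scatter), and a 3.8-fold higher number from compound 1 to compound 4 (0.58 log units; beyond the scatter). In a physicochemical assay for solubility, with a stated time of 18 h, at pH 7.4 (a lower number here means a less soluble compound, a higher number a more soluble compound), compound 3 gives 4200 nM and compound 4 gives 32000 nM, so this same swap, small in the cell read-out, shifts solubility clearly: the measured solubility of compound 3, 4200 nM, and of compound 4, 32000 nM, a 7.6-fold higher number (0.88 log units; beyond the scatter)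

Still open, as far as these compounds go, is how an amine or a carboxylic acid on the naphthalen-1-yl group would move these two read-outs.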